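The source may hold more compounds than are shown below. What is called first, only, known or untested is meant among the compounds shown, and "the series" means these compounds.

Measured so far in a functional assay on a cell-free system (plasma, Homo sapiens), with a stated time of 3 min; on this read-out higher numbers stand for weaker inhibition and lower numbers for stronger inhibition:
compound 1 `CC(C)(C)C[C@@H](O)C(=O)N1NCC[C@H]1C(=O)NCc1cc(Cl)ccc1-n1cnnn1` gives 1300 nM
compound 2 `O=C(NCc1cc(Cl)ccc1-n1cnnn1)[C@@H]1C[C@@H]2C[C@@H]2N1C(=O)[C@H](O)c1ccccc1F` gives 770 nM
compound 3 `O=C(NCc1cc(Cl)ccc1-n1cnnn1)[C@@H]1[C@@H]2C[C@@H]2CN1C(=O)[C@H](O)c1ccccc1F` gives 580 nM

Compound 2 holds the second highest of the three numbers in this assay; its gap to compound 3 and its gap to compound 1 both fall within the usual scatter, so the three stand on a par. The step to compound 4 `O=C(NCc1cc(Cl)ccc1-n1cnnn1)[C@@H]1C[C@@H]2C[C@@H]2N1C(=O)[C@H](O)C1CCCCC1` changes one place: cyclohexyl in place of 2-fluorophenyl on a saturated chain carbon bound to a carbonyl carbon and an oxygen on a saturated carbon. Going by the values given here, no pair of measured compounds differs in this way, so the size of the step rests on no precedent. Among the three measured compounds, the differences in structure have shifted the number only within the scatter, so for compound 4 the expected step of a 1.2-fold higher number from compound 2 to compound 4 (0.07 log units; within the scatter) is none beyond the scatter, with either direction possible. Compound 4 is estimated at 900 nM in this assay, within 400 nM to 2000 nM.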

Compound 4, half-maximal inhibitory concentration: 600 nM
Compound 4: middle estimate off by 1.5-fold (0.18 log units), on the high side; the measured number falls inside the stated range.
By their numbers in this assay, from the lowest: compounds 3, 4, 2 and 1 (each within the scatter of the next, the first and the last beyond it).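

In this assay, going by these compounds alone, this is the first pair that differs in one place: cyclohexyl in place of 2-fluorophenyl gives a 1.3-fold lower number from compound 2 to compound 4 (0.11 log units; within the scatter). At this position, then, a six-membered aromatic ring of carbon carrying fluorine and a six-membered non-aromatic ring of carbon stand level. No evidence at hand bears on this result.

As far as these compounds go, whether a carboxylic acid or an amine at this position would move the number beyond the scatter stays open. So does whether cyclohexyl gives the same result on the core of compound 3.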